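Bromo to Methyl: a Step Awaiting Its Number

The source may report more compounds than this note shows. Statements on the series, on what has been measured and on what is new or still open speak of the compounds shown alone.

Compound 1, `O=c1ccoc2ccc(OCCCc3ccccc3)cc12`: 1910 nM
Compound 2, `O=c1ccoc2ccc(OCc3ccc(Br)cc3)cc12`: 95 nM

Of the compounds shown here, two sharing one core have been measured so far. In an assay on microsomes for inhibition of Amine oxidase [flavin-containing] A (Homo sapiens), read by fluorescence and spectrophotometry, with a stated time of 20 min (a lower number here means a stronger inhibitor, a higher number a weaker inhibitor), compound 1 gives 1910 nM. In this assay, for the measured compounds named here, compound 2 gives 95 nM, the lower of the two numbers and thus the stronger inhibitor; compound 1, the only other compound, sits far above it, a gap that lies beyond the scatter of repeated measurements. The two differ in more than one place, so no single structural cause can be read out of that gap.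

The next compound, compound 3, `Cc1ccc(COc2ccc3occc(=O)c3c2)cc1`, differs from compound 2 in just one place: methyl in place of bromo on an aromatic carbon. Going by the values given here, no measured pair in this set shows the effect of exactly this exchange, so there is nothing to lean on beyond the general experience that swapping one small group for another of the same size on a ring often moves the number only a little. Compound 3 is therefore expected to land near compound 2, around 150 nM, within a range from 50 nM to 500 nM. The step from compound 2 to compound 3 in this assay is expected to be a 1.6-fold higher number from compound 2 to compound 3 (0.20 log units; within the scatter), a small move that might not exceed the scatter.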

Compound 3, half-maximal inhibitory concentration: 3490 nM
Estimate against measurement, compound 3: 23-fold (1.37 log units) below, outside the stated range (above it).
By their numbers in this assay, from the lowest: compound 2; then compounds 1 and 3 (each within the scatter of the next).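

In this assay, methyl in place of bromo gives a 37-fold higher number from compound 2 to compound 3 (1.57 log units; beyond the scatter) and so shows that this place on the aromatic ring, para to a large group, is highly sensitive to which small group sits there. Bromo and methyl match on everything counted here, each being one heavy atom with no ring, no hydrogen-bond donors or acceptors and no net charge, so these counts do not separate the two groups even though the step lies beyond the scatter. Nothing measured here accounts for the size of this step, and what distinguishes bromo from methyl at this place remains unexplained.

The compounds shown leave open whether other groups at this place, such as chloro, methoxy or a nitrile, would give numbers near that of compound 2 or near that of compound 3. Also open, from the compounds shown here alone, is how bromo would behave on a longer chain, a question compound 1 cannot answer, as it differs from compound 2 in more than one place.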